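Sulfonyl substituent change within the shared core

This account rests on a few compounds, and the source may have more. Where it says the series, first, only, none or still open, it means among the compounds named here.

Among the compounds with values here, compound 2 `CS(=O)(=O)n1ccc2ccc(-c3ccncc3)cc21` gives 4050 nM in an assay on isolated protein for displacement of a labelled ligand from 5-hydroxytryptamine receptor 6 (Homo sapiens), read by scintillation counting, with a stated time of 1 h (a lower number here means a stronger inhibitor, a higher number a weaker inhibitor), the lower of the two numbers measured so far; compound 1 `CN(C)c1cccc2c1ccn2S(=O)(=O)N1CCCCC1` gives 39100 nM in this assay, and the gap between the two lies beyond the usual scatter. Within the data shown here, no pair of measured compounds differs in one place only, so the change to compound 3 `O=S(=O)(C1CCCCC1)n1ccc2ccc(-c3ccncc3)cc21` has no measured precedent. The difference is cyclohexyl in place of methyl on a sulfonyl sulfur. With nothing measured at this position, the size of the step in this assay rests on the structural change alone; a move to a lower number, beyond the scatter, is expected, though a step within the scatter cannot be ruled out. The estimate for compound 3 is 800 nM, with a range of 150 nM to 4000 nM. This corresponds to an expected step of a 5.1-fold lower number from compound 2 to compound 3 (0.70 log units; beyond the scatter).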

Compound 3, inhibition constant: 2180 nM
Beside the measured number, compound 3's estimate is 2.7-fold (0.44 log units) below it; measured number inside the range.
By their numbers in this assay, from the lowest: compounds 3 and 2 (each within the scatter of the next); then compound 1.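

Within the data shown here, the first one-place comparison shows that, in this assay, cyclohexyl in place of methyl on a sulfonyl sulfur gives a 1.9-fold lower number from compound 2 to compound 3 (0.27 log units; within the scatter) and leaves the two compounds indistinguishable. On the shared core, this sulfonyl sulfur therefore carries 6 heavy atoms and a non-aromatic ring of carbon as well as it carries the 1 heavy atom of methyl, with no difference that can be read from this assay. No evidence in hand bears on this result.

Still open, as far as these compounds go, is whether phenyl, or a longer chain such as n-butyl, on the sulfonyl sulfur would give a step beyond the scatter. Also open, from the compounds shown here alone, is how an amine at this place would read on the same core, since compound 1 differs from compound 2 and compound 3 in more than one place and offers no comparison.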